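A few compounds are considered here, and "the series" means these few. Any claim that something is new, unique, unknown or untested is made for them only; others in the source may bear on it.

Compound 1 `N/C(=N\NC(=S)N1CCCCCC1)c1ccccn1` and compound 2 `N/C(=N\NC(=S)N1CCCCC1)c1ccccn1` share the same core apart from the ring attached to the thiocarbonyl group; how the two cores differ is not broken down here. In a functional assay on MCF7 cells (Homo sapiens) for cytotoxicity, read by MTT assay, with a stated time of 72 h, tested at 1 uM (a lower number here means less inhibition of growth, a higher number more inhibition of growth at the concentration tested), compound 1 gives 25.3%, and compound 2 gives 15.4% in this assay; the two numbers sit within the usual scatter of each other, so they cannot be placed in any order.

Compound 3 `Cc1cccc(/C(N)=N/NC(=S)N2CCCCC2)n1` is compound 2 carrying one more group: methyl in place of hydrogen on an aromatic carbon. This gives compound 3 a reading of 19.5% in this assay, so the change a number 4.1 percentage points higher from compound 2 to compound 3 (within the scatter) did not move the number in a way that can be told from noise.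

Compound 4 `Cc1ccnc(/C(N)=N/NC(=S)N2CCCCCC2)c1` is not yet measured. It stands to compound 1 as compound 3 stands to compound 2: methyl in place of hydrogen on an aromatic carbon. The two changes are the same kind of change, not the same one. The methyl group in compound 3 sits next to the ring nitrogen, whereas in compound 4 it sits opposite the ring nitrogen, each being meta to a large group.

Going by the values given here, the only comparable step in hand, from compound 2 to compound 3, stayed within the scatter, and compound 1 itself reads 25.3% in this assay, so the expected step from compound 1 to compound 4 is also small, about a number 2.7 percentage points higher from compound 1 to compound 4 (within the scatter). Compound 4 is therefore estimated to give around 28% in this assay, with a likely range from 15% to 42%.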

Compound 4, percent growth inhibition at one concentration: 18.2%
Estimate against measurement, compound 4: 9.8 percentage points above; the range from low to high includes it.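

In this assay, methyl in place of hydrogen on an aromatic carbon, here opposite the ring nitrogen, gives a number 7.1 percentage points lower from compound 1 to compound 4 (within the scatter), so this step cannot be told from noise. Set beside the earlier step on the other core, the new step gives no sign that the change behaves differently from one core to the other: the same change on two cores in this assay, a number 4.1 percentage points higher (within the scatter) from compound 2 to compound 3 and a number 7.1 percentage points lower (within the scatter) from compound 1 to compound 4, 11.2 percentage points apart, within the scatter of two such steps

This does not show that the change carries over with a dependable effect, as neither step can be told from noise, and the two steps are not an exact match either: the core differs, and the methyl does not sit in the same place in compound 3 as in compound 4, so any influence of the core cannot be separated from that of the position.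

The compounds shown leave open whether a group other than methyl on this aromatic ring, such as an amine, a methoxy group or a chlorine atom, would produce a step that stands clear of the scatter. They also leave open what the same methyl would do in the same place on both cores, and how the compounds would compare at other concentrations.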